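Trifluoromethyl for Chloro on the Urea Aryl of Compound 2

This account rests on a few compounds, and the source may have more. Where it says the series, first, only, none or still open, it means among the compounds named here.

Compound 1, `COc1cc(-c2nn(-c3cccc(NC(=O)Nc4ccc(Cl)c(Cl)c4)c3)cc2-c2ccncc2)ccc1Cl`, gives 954 nM in a functional assay on LOX IMVI cells (Homo sapiens) for inhibition, read by sulforhodamine B assay, with a stated time of 48 h; on this read-out higher numbers stand for weaker inhibition of growth and lower numbers for stronger inhibition of growth. Compound 2, `O=C(Nc1cccc(-n2cc(-c3ccncc3)c(-c3ccc(Cl)c(O)c3)n2)c1)Nc1ccc(Cl)c(Cl)c1`, gives 939 nM. Compound 3, `COc1cc(-c2nn(-c3cccc(NC(=O)c4ccc(Cl)c(C(F)(F)F)c4)c3)cc2-c2ccncc2)ccc1Cl`, gives 1920 nM.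

Compound 2 holds the lowest of the three numbers in this assay, but its nearest neighbour is compound 1, and the step of a 1.0-fold lower number from compound 1 to compound 2 (0.01 log units; within the scatter) lies within the scatter, so the two cannot be ordered. Only compound 3 stands beyond the scatter from compound 2.

Compound 4, `O=C(Nc1cccc(-n2cc(-c3ccncc3)c(-c3ccc(Cl)c(O)c3)n2)c1)Nc1ccc(Cl)c(C(F)(F)F)c1`, differs from compound 2 in one place: trifluoromethyl in place of chloro on an aromatic carbon. Going by the values given here, the one measured step that touches this change is a 2.0-fold higher number from compound 1 to compound 3 (0.30 log units; within the scatter), where the same exchange of chloro for trifluoromethyl came together with a change from a urea to an amide, so it cannot be read as the effect of the trifluoromethyl alone. The methyl-to-hydrogen step from compound 1 to compound 2 tells nothing about this position. With a single, confounded and small step as guide, the expectation for compound 4 in this assay is a step of a 1.3-fold higher number from compound 2 to compound 4 (0.11 log units; within the scatter), a slight weakening at most, not beyond the scatter. Compound 4 is therefore estimated at 1200 nM, with a range from 500 nM to 2800 nM.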

Compound 4, concentration for 50% growth inhibition: 554 nM
For compound 4 the middle estimate is 2.2-fold (0.34 log units) above the measured one; the measured number falls inside the stated range.
By their numbers in this assay, from the lowest: compounds 4, 2, 1 and 3 (each within the scatter of the next, the first and the last beyond it).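

In this assay, the step of a 1.7-fold lower number from compound 2 to compound 4 (0.23 log units; within the scatter) shows trifluoromethyl in place of chloro on this ring with the urea left untouched, so the exchange can now be read on its own, and compound 2 and compound 4 cannot be ordered. The earlier step of a 2.0-fold higher number from compound 1 to compound 3 (0.30 log units; within the scatter) had joined the same exchange to a change from urea to amide, whereas this pair shows that four heavy atoms can stand in place of one on this aromatic carbon, ortho to a chloro group, with no loss of growth inhibition beyond the scatter. No measurement at hand offers any explanation for how this exchange reads in the cells.

The compounds shown carry only chloro and trifluoromethyl at this place, so it remains open how a nitrile, a methyl group, a bromo group or a methoxy group would read there. Also open, from the compounds shown here alone, is how a urea and an amide compare when the aryl group on the carbonyl carbon is held the same, and whether this exchange reads alike in other cell lines.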